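Removing one bromine from the salicylamide of compound 2

The source may hold more compounds than are shown below. What is called first, only, known or untested is meant among the compounds shown, and "the series" means these compounds.

Among the compounds with values here, compound 2 `O=C(Nc1ccc(Sc2nc3ccccc3s2)cc1)c1cc(Br)cc(Br)c1O` is the only compound of this pair with a number in an assay for inhibition of HSP60/HSP10 (Homo sapiens), with a stated time of 60 min; a higher number here means a weaker inhibitor, a lower number a stronger inhibitor; compound 2 gives 4700 nM. Its companion, compound 1 `O=C(Nc1ccc(Sc2nc3ccccc3s2)cc1)c1ccccc1O`, reached only a limit of this assay: in this assay compound 1 gives > 100000 nM. Within the data shown here, the step between them, an at least 21-fold lower number from compound 1 to compound 2 (1.32 log units; beyond the scatter), is the one measured step here, and it rests on (the limit of > 100000 nM in this assay, at which 1 of the 2 values shown sits).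

Compound 3 `O=C(Nc1ccc(Sc2nc3ccccc3s2)cc1)c1cc(Br)ccc1O` takes the change (hydrogen in place of bromo on an aromatic carbon), so that the 3,5-dibromo-2-hydroxyphenyl becomes a 5-bromo-2-hydroxyphenyl. This is half of the change that separates compound 1 from compound 2, walked backwards. Since the full change from compound 1 to compound 2 was large, the loss of one bromine, the one ortho to the hydroxy group, is expected to move the number back toward that of compound 1, though by how much of the whole step cannot be read from two points. The step from compound 2 to compound 3 in this assay is therefore expected to be a 4.3-fold higher number from compound 2 to compound 3 (0.63 log units; beyond the scatter). Compound 3 is estimated at 20000 nM, in a range from 6000 nM to 80000 nM, with a real chance that only a limit is reported.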

Compound 3, half-maximal inhibitory concentration: > 100000 nM
Compound 3: no number, only a limit; the forecaster's own chance of this, stated with the estimate: 25%; at least 5.0-fold (0.69 log units) between middle value and limit.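

In this assay, hydrogen in place of bromo, ortho to a hydroxy group, gives an at least 21-fold higher number from compound 2 to compound 3 (1.32 log units; beyond the scatter), so the remaining 5-bromo-2-hydroxyphenyl is not enough to keep a measured number. Compound 1 and compound 2 differ by two bromines at once and could not show what a single bromine does; compound 3 now shows that the bromine at this position cannot be removed without the number being lost to the limit of the assay. Compound 3 gives > 100000 nM, which is a limit, and the step between compound 1 and compound 3 cannot be read, while the size of the loss from compound 2 stays a lower bound: the limit of > 100000 nM in this assay, at which 2 of the 3 values shown sit.

Going by these compounds, whether a bromo ortho to the hydroxy group would give a number without the second bromo stays open, as does how far the true value of compound 3 lies from the limit. Also open, on these data alone, is whether chloro, methyl or another group on this aromatic carbon would hold the number of compound 2 or lose it as hydrogen does.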